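Lengthening the Hydroxycarbamoyl Chain on Two Different Cores

A few compounds are considered here, and "the series" means these few. Any claim that something is new, unique, unknown or untested is made for them only; others in the source may bear on it.

Compound 1 `Nc1ncnc2c1c(-c1cnc3[nH]ccc3c1)nn2CCCCCC(=O)NO` and compound 2 `Nc1ncnc2c1c(-c1cnc3[nH]ccc3c1)nn2CCCCCCC(=O)NO` share one core, while compound 3 `Nc1nc2cc(-c3nn(CCCCC(=O)NO)c4ncnc(N)c34)ccc2o1` and compound 4 `Nc1nc2cc(-c3nn(CCCCCC(=O)NO)c4ncnc(N)c34)ccc2o1` share another; the difference between the two cores is not broken down here. In a functional assay on Huh-7 cells (Homo sapiens) for inhibition, read by MTT assay, with a stated time of 72 h (on this read-out lower numbers stand for stronger inhibition and higher numbers for weaker inhibition), compound 1 gives only a limit, > 100000 nM, which is the limit of > 100000 nM in this assay, at which 1 of the 3 values shown sits. In this assay compound 2 gives 50900 nM and compound 3 gives 9220 nM. The change from compound 1 to compound 2 is (hydroxycarbamoyl)methyl in place of hydroxycarbamoyl on a saturated chain carbon, five bonds along the chain from an aromatic nitrogen, and it produced an at least 1.9-fold lower number from compound 1 to compound 2 (0.29 log units; that floor lies within the scatter).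

Compound 4 carries the same kind of change relative to compound 3, namely ((hydroxycarbamoyl)methyl in place of hydroxycarbamoyl on a saturated chain carbon, four bonds along the chain from an aromatic nitrogen); the place differs in that the chain carbon is four bonds along the chain from an aromatic nitrogen rather than five. Compound 4 has not yet been measured in this assay. Resting on the measured step of an at least 1.9-fold lower number from compound 1 to compound 2 (0.29 log units; that floor lies within the scatter), compound 4 is expected to show a 2.0-fold lower number from compound 3 to compound 4 (0.31 log units; beyond the scatter). The estimate for compound 4 in this assay is 4500 nM, expected to fall between 1500 nM and 15000 nM.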

Compound 4, half-maximal inhibitory concentration: 9910 nM
Beside the measured number, compound 4's estimate is 2.2-fold (0.34 log units) below it, within the range that was stated.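

On the core shared by compound 3 and compound 4, swapping hydroxycarbamoyl for (hydroxycarbamoyl)methyl gives a 1.1-fold higher number from compound 3 to compound 4 (0.03 log units; within the scatter) in this assay, so on this core the two chain lengths cannot be told apart. This does not show that the change behaves differently on the two cores, nor that it behaves the same, since the earlier step starts from a compound with a limit rather than a number, and the comparison stays unsettled: the same change on two cores in this assay, an at least 1.9-fold lower number (0.29 log units; that floor lies within the scatter) from compound 1 to compound 2 and a 1.1-fold higher number (0.03 log units; within the scatter) from compound 3 to compound 4; the limit leaves it open whether they differ What the pairs do show is narrower: the change that could be followed on the core of compound 1 gave no measurable shift in the number on the core of compound 3, and one of the four compounds rests on a limit alone: the limit of > 100000 nM in this assay, at which 1 of the 4 values shown sits.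

The compounds shown leave open what a longer chain on either core, or a carboxylic acid or an amine in place of the hydroxycarbamoyl group, would do in this assay. Two pairs are also too few to set a trend along the chain for either core.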